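This account rests on a few compounds, and the source may have more. Where it says the series, first, only, none or still open, it means among the compounds named here.

Three compounds share one core and differ only in the aryl group attached to an aromatic nitrogen. Compound 1 `CC1(C)[C@H]2CC[C@]1(C)N(Cc1cn(-c3cccc(Cl)c3)nn1)C(=O)C2` carries a 3-chlorophenyl group, compound 2 `CC1(C)[C@H]2CC[C@]1(C)N(Cc1cn(-c3ccc(Cl)cc3)nn1)C(=O)C2` a 4-chlorophenyl group, and compound 3 `CC1(C)[C@H]2CC[C@]1(C)N(Cc1cn(-c3ccc(F)cc3)nn1)C(=O)C2` a 4-fluorophenyl group. In a functional assay on PANC-1 cells (Homo sapiens) for inhibition, read by MTT assay, with a stated time of 24 h (on this read-out lower numbers stand for stronger inhibition and higher numbers for weaker inhibition), compound 1 gives 260 nM, compound 2 gives 440 nM and compound 3 gives 110 nM. Compound 3 thus has the lowest of the three numbers: the step of a 2.4-fold lower number from compound 1 to compound 3 (0.37 log units; beyond the scatter) and the step of a 4.0-fold lower number from compound 2 to compound 3 (0.60 log units; beyond the scatter) both lie beyond the scatter, while the step of a 1.7-fold higher number from compound 1 to compound 2 (0.23 log units; within the scatter) does not.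

Compound 4 `CC1(C)[C@H]2CC[C@]1(C)N(Cc1cn(-c3cccc(Br)c3)nn1)C(=O)C2` has not yet been measured. It differs from compound 3 in one place: 3-bromophenyl in place of 4-fluorophenyl on an aromatic nitrogen. The measured step that bears most directly on this change is a 2.4-fold lower number from compound 1 to compound 3 (0.37 log units; beyond the scatter), since compound 1 also carries a 3-chlorophenyl group. Bromine in place of chlorine on that group has no measured step among these compounds, so that part of the change is unknown. Running the measured step backwards suggests a higher number for compound 4 than for compound 3, by a modest margin. The estimate for compound 4 in this assay is 280 nM, with a range from 120 nM to 700 nM. This would mean an expected step of a 2.5-fold higher number from compound 3 to compound 4 (0.41 log units; beyond the scatter).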

Compound 4, half-maximal inhibitory concentration: 90 nM
For compound 4 the middle estimate is 3.1-fold (0.49 log units) above the measured one, outside the stated range (below it).
By their numbers in this assay, from the lowest: compounds 4 and 3 (each within the scatter of the next); then compounds 1 and 2 (each within the scatter of the next).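

Among the compounds shown here, the first measured halogen swap on this group, from chlorine to bromine, gives in this assay a 2.9-fold lower number from compound 1 to compound 4 (0.46 log units; beyond the scatter), so the halogen on the ring matters even when its place stays the same. The 3-bromophenyl group also shows that a low number here does not need the 4-fluorophenyl group: a 1.2-fold lower number from compound 3 to compound 4 (0.09 log units; within the scatter) lies within the scatter, which leaves these two groups unranked, whereas a 4.9-fold lower number from compound 2 to compound 4 (0.69 log units; beyond the scatter) keeps the 4-chlorophenyl group clearly apart from the 3-bromophenyl group. No measurement shown here explains why these aryl groups differ.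

The halogen and its place on the ring are never varied fully among these compounds, so the effect of each cannot be separated without the matching 4-bromophenyl and 3-fluorophenyl groups. From the compounds shown here alone, it also remains open whether this aromatic nitrogen accepts a phenyl ring carrying something other than a halogen, such as a methoxy group, an amine or a carboxylic acid, or a group with no phenyl ring at all, such as a short alkyl chain.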